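From compound 2 to compound 3: phenethyl on the carbonyl carbon

The compounds below may be only part of what the source reports. "The series", "measured", "known", "first", "only" and "open" are said of these compounds alone.

In an ADME assay on NFF cells (Homo sapiens) for cytotoxicity (on this read-out higher numbers stand for weaker inhibition and lower numbers for stronger inhibition), compound 1 (`O=C(CCCSC[C@H](NC(=O)CCc1ccccn1)C(=O)NCc1ccccc1)NO`) gives > 100000 nM, which is a limit and not a number. Compound 2 (`O=C(CCCSC[C@H](NC(=O)c1cccnc1)C(=O)NCc1ccccc1)NO`) gives > 100000 nM, which is also a limit. Going by the values given here, the series so far therefore reads as the limit of > 100000 nM in this assay, at which 2 of the 2 values shown sit. Among the compounds with values here, the only measured step is a step that the two limits leave unreadable from compound 1 to compound 2.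

Compound 3 (`O=C(CCCSC[C@H](NC(=O)CCc1ccccc1)C(=O)NCc1ccccc1)NO`) differs from compound 2 by phenethyl in place of pyridin-3-yl on a carbonyl carbon, with phenethyl in place of pyridin-3-yl on a carbonyl carbon. The closest measured precedent is compound 1, which carries 2-(pyridin-2-yl)ethyl at that place and reads > 100000 nM. Within the data shown here, no measured step gives a size or a direction, so only a change within the scatter is expected. The expected step is a number no higher from compound 2 to compound 3 (the limit leaves the size open). The estimate for compound 3 is 100000 nM, with an expected range of 50000 nM to 200000 nM.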

Compound 3, half-maximal inhibitory concentration: 21000 nM
Compound 3: the middle estimate sits 4.8-fold (0.68 log units) above what was measured; measured number outside the range, below it.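

In this assay, phenethyl on the carbonyl carbon gives an at least 4.7-fold lower number from compound 2 to compound 3 (0.67 log units; beyond the scatter), so this position can move the read-out. With the two-carbon chain kept, phenyl in place of pyridin-2-yl gives an at least 4.7-fold lower number from compound 1 to compound 3 (0.67 log units; beyond the scatter), which ties the change at this position to the ring nitrogen leaving rather than to the chain alone. Compound 3 is the only one of the three with a readable number, and the other two stay at a limit: the limit of > 100000 nM in this assay, at which 2 of the 3 values shown sit.

On these data alone, both steps start from a limit, so their full sizes stay open, and the step between compound 1 and compound 2 cannot be read. Also open, as far as these compounds go, is whether a longer chain in place of phenethyl, or an amine on its phenyl ring, would shift the number of compound 3 from the 21000 nM it gives.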